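From Fluoro to Methoxy on the Amide Aryl Ring

This account rests on a few compounds, and the source may have more. Where it says the series, first, only, none or still open, it means among the compounds named here.

Measured compounds:
compound 1 `CN(C(=O)c1ccccc1)c1ccc2[nH]c(-c3n[nH]c4ccccc34)cc2n1` gives 8580 nM
compound 2 `CN(C(=O)CCc1ccccc1)c1ccc2[nH]c(-c3n[nH]c4ccccc34)cc2n1` gives 7380 nM
compound 3 `CN(C(=O)c1ccc(F)cc1)c1ccc2[nH]c(-c3n[nH]c4ccccc34)cc2n1` gives 7220 nM

The three compounds were tested in a functional assay on KB cells (Homo sapiens) for antiproliferative activity, read by MTT assay, with a stated time of 72 h; a higher number here means a weaker inhibitor, a lower number a stronger inhibitor. Compound 3 has the lowest of the three numbers, but its distance to the others is small: a 1.0-fold lower number from compound 2 to compound 3 (0.01 log units; within the scatter) and a 1.2-fold lower number from compound 1 to compound 3 (0.07 log units; within the scatter), so compound 3 cannot be called stronger than compound 1 or compound 2. Compound 4 `COc1ccc(C(=O)N(C)c2ccc3[nH]c(-c4n[nH]c5ccccc45)cc3n2)cc1` has not yet been measured. It differs from compound 3 in one place: methoxy in place of fluoro on an aromatic carbon.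

The step that bears most directly on this change is a 1.2-fold lower number from compound 1 to compound 3 (0.07 log units; within the scatter), since it also alters the same position of the same ring, and it stayed within the scatter. The larger change a 1.2-fold lower number from compound 1 to compound 2 (0.07 log units; within the scatter) likewise moved nothing beyond the scatter. Every step seen so far is flat, so for compound 4 no step beyond the scatter is expected: a 1.0-fold lower number from compound 3 to compound 4 (0.00 log units; within the scatter). Compound 4 is therefore estimated at 7200 nM, with a range of 3600 nM to 14400 nM.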

Compound 4, half-maximal inhibitory concentration: 12900 nM
For compound 4 the middle estimate is 1.8-fold (0.25 log units) below the measured one; the range from low to high includes it.
By their numbers in this assay, from the lowest: compounds 3, 2, 1 and 4 (each within the scatter of the next).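

In this assay, methoxy on this aromatic carbon, para to a large group, stays within the scatter against both fluoro (a 1.8-fold higher number from compound 3 to compound 4 (0.25 log units; within the scatter)) and hydrogen (a 1.5-fold higher number from compound 1 to compound 4 (0.18 log units; within the scatter)), although it enters with one more heavy atom than fluoro and one hydrogen-bond acceptor. Replacing phenethyl on the carbonyl carbon with 4-methoxyphenyl also stays within the scatter (a 1.7-fold higher number from compound 2 to compound 4 (0.24 log units; within the scatter)), so this is the largest step seen so far, yet none of the steps separates the four compounds. No evidence is available to explain these small differences.

The compounds shown do not tell whether an amine or a carboxylic acid at this position would move the number beyond the scatter. They also leave open whether a longer chain on the carbonyl carbon would do so.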